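The source may report more compounds than this note shows. Statements on the series, on what has been measured and on what is new or still open speak of the compounds shown alone.

Measured compounds:
- compound 1 `O=C(N/N=C/c1ccc(F)cc1)Nc1cc2c(Nc3ccc(F)c(Cl)c3)ncnc2cc1O[C@H]1CCOC1` in a functional assay on HepG2 cells (Homo sapiens) for cytotoxicity, read by MTT assay, with a stated time of 72 h (on this read-out higher numbers stand for weaker inhibition and lower numbers for stronger inhibition), gives "not active" (no number reported)
- compound 2 `N#Cc1ccc(/C=N/NC(=O)Nc2cc3c(Nc4ccc(F)c(Cl)c4)ncnc3cc2O[C@H]2CCOC2)cc1` in this assay gives 26400 nM
- compound 3 `O=C(N/N=C/c1ccc(F)cc1Cl)Nc1cc2c(Nc3ccc(F)c(Cl)c3)ncnc2cc1O[C@H]1CCOC1` in this assay gives 26100 nM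

Compound 3 carries the lowest of the two numbers that exist; its nearest neighbour is compound 2, and the step of a 1.0-fold lower number from compound 2 to compound 3 (0.00 log units; within the scatter) lies within the scatter, so no order can be read between them. Compound 1, with the third variation of the same aryl group, returned no number at all. The series therefore shows three aryl groups on the carbon with a double bond to nitrogen, two giving practically the same weak number and one giving none.

Compound 4 `COc1ccc(/C=N/NC(=O)Nc2cc3c(Nc4ccc(F)c(Cl)c4)ncnc3cc2O[C@H]2CCOC2)c(OC)c1OC` continues this line: 2,3,4-trimethoxyphenyl in place of 2-chloro-4-fluorophenyl on a carbon with a double bond to nitrogen. Among the measured compounds shown here, the one measured step that bears on such a change, a 1.0-fold lower number from compound 2 to compound 3 (0.00 log units; within the scatter), was flat, so changing this aryl group between two substituted phenyls left the number unchanged. Compound 1 reminds that the same position can also lose activity altogether.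

For compound 4 the expectation in this assay is a step of a 1.0-fold lower number from compound 3 to compound 4 (0.00 log units; within the scatter) of no size beyond the scatter, although the outcome of compound 1 keeps a real chance that only a limit is reported. Compound 4 is estimated at 26000 nM, with a range from 9000 nM to 70000 nM.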

Compound 4, half-maximal inhibitory concentration: 29300 nM
Compound 4: middle estimate off by 1.1-fold (0.05 log units), on the low side; the measured number falls inside the stated range.
By their numbers in this assay, from the lowest: compounds 3, 2 and 4 (each within the scatter of the next).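

In this assay the new compound gives a 1.1-fold higher number from compound 3 to compound 4 (0.05 log units; within the scatter) and also a 1.1-fold higher number from compound 2 to compound 4 (0.05 log units; within the scatter) so 2,3,4-trimethoxyphenyl on a carbon with a double bond to nitrogen cannot be told apart from either 2-chloro-4-fluorophenyl or 4-cyanophenyl at this place. Before, this flat reading rested on a single pair of aryl groups; it now spans three, and it holds even though the entering group has three methoxy groups, three hydrogen-bond acceptors and no halogen, while the 2-chloro-4-fluorophenyl it replaces has no hydrogen-bond acceptors and carries chlorine and fluorine. Among the compounds shown here, compound 1, reported as "not active" (no number reported) without a number, remains the one compound that goes against this picture.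

Nothing given here explains either the closeness of the three numbers or the outcome of compound 1. Open, going by these compounds, is whether any aryl group is needed on this carbon, and whether a dimethylamino group or a carboxylic acid on the phenyl ring, or a cyclohexyl group in its place, would move the number beyond the scatter.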